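The source may report more compounds than this note shows. Statements on the series, on what has been measured and on what is new or still open speak of the compounds shown alone.

Working notes on the series. In a functional assay on A549 cells (Homo sapiens) for inhibition, read by colorimetric assay and MTT assay, with a stated time of 72 h (on this read-out higher numbers stand for weaker inhibition and lower numbers for stronger inhibition), compound 1 (`Cn1c2cnc1OCCCCCCCCOc1cc3ccccc3cc1-2`) gives 26000 nM and compound 2 (`CCCCOc1ncc(-c2ccccc2OC)n1C`) gives 87000 nM. Compound 2 therefore carries the higher number of the two, meaning the weaker inhibition, and its gap to compound 1 lies beyond the scatter. Compound 3 (`C=CCCOc1ncc(-c2ccccc2OC)n1C`) has vinyl in place of ethyl on a saturated chain carbon, two bonds along the chain from an oxygen on an aromatic ring. Among the measured compounds shown here, no measured pair shows this change, so the data give no direct size for it. No shift beyond the scatter is expected in this assay, and neither direction is favoured. The expected size of the change is a 1.1-fold lower number from compound 2 to compound 3 (0.04 log units; within the scatter). For compound 3 the estimated value is 80000 nM, with an estimated range of 38000 nM to 160000 nM.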

Compound 3, half-maximal inhibitory concentration: 22000 nM
Beside the measured number, compound 3's estimate is 3.6-fold (0.56 log units) above it, outside the stated range (below it).
By their numbers in this assay, from the lowest: compounds 3 and 1 (each within the scatter of the next); then compound 2.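

In this assay, vinyl in place of ethyl on a saturated chain carbon, two bonds along the chain from an oxygen on an aromatic ring, gives a 4.0-fold lower number from compound 2 to compound 3 (0.60 log units; beyond the scatter), the first measured size for this change in the series. Both groups hold 2 heavy atoms and the entering vinyl adds 1 double bond outside aromatic rings, so the read-out at this position shifts with no change in heavy-atom count. Nothing available bears on the cause of this step.

On these data alone, it remains open whether an ethynyl group, a longer chain such as pent-4-en-1-yl, or an amine at the same place would follow the same direction. This single pair also leaves open whether the change carries over to any other core.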